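The source may report more compounds than this note shows. Statements on the series, on what has been measured and on what is new or still open speak of the compounds shown alone.

Measured so far:
Compound 1 `COc1ccc(-c2cn3cc(C4=CCN(S(=O)(=O)CCc5ccccc5)CC4)ccc3n2)cc1OC`: 7690 nM
Compound 2 `COc1ccc(-c2cn3cc(C4=CCN(C(=O)C5CCCCC5)CC4)ccc3n2)cc1OC`: 7310 nM
Compound 3 `COc1ccc(-c2cn3cc(C4=CCN(C(=O)C(C)(C)C)CC4)ccc3n2)cc1OC`: 4340 nM

In a functional assay on A549 cells (Homo sapiens) for antiproliferative activity, read by MTT assay, with a stated time of 48 h (on this read-out lower numbers stand for stronger inhibition and higher numbers for weaker inhibition), compound 2 stands second highest of these three numbers, with compound 1 nearest to it and compound 3 furthest. Compound 4 `COc1ccc(-c2cn3cc(C4=CCN(S(=O)(=O)c5ccccc5)CC4)ccc3n2)cc1OC` differs from compound 2 in one place: phenylsulfonyl in place of cyclohexylcarbonyl on an amine nitrogen in a ring. The step that bears most on this change is the exchange of a sulfonyl for a carbonyl on the same nitrogen, a 1.1-fold lower number from compound 1 to compound 2 (0.02 log units; within the scatter). The other two steps, a 1.8-fold lower number from compound 1 to compound 3 (0.25 log units; within the scatter) and a 1.7-fold lower number from compound 2 to compound 3 (0.23 log units; within the scatter), are also small. None of them shows a shift beyond the scatter, so compound 4 is expected to give a number close to that of compound 2, a 1.0-fold lower number from compound 2 to compound 4 (0.02 log units; within the scatter). The estimate for compound 4 is 7000 nM, with a range from 3000 nM to 16000 nM.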

Compound 4, half-maximal inhibitory concentration: 7660 nM
The estimate for compound 4 lay 1.1-fold (0.04 log units) below the measured number; the range from low to high includes it.
By their numbers in this assay, from the lowest: compounds 3, 2, 4 and 1 (each within the scatter of the next).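

In this assay, an aromatic phenylsulfonyl on the amine nitrogen in the ring stands level with the non-aromatic cyclohexylcarbonyl (a 1.0-fold higher number from compound 2 to compound 4 (0.02 log units; within the scatter)), so both the ring type and the linking group differ here with no shift beyond the scatter. Phenyl in place of phenethyl on the sulfonyl sulfur (a 1.0-fold lower number from compound 1 to compound 4 (0.00 log units; within the scatter)) and phenylsulfonyl in place of (tert-butyl)carbonyl (a 1.8-fold higher number from compound 3 to compound 4 (0.25 log units; within the scatter)) also stay within the scatter. Nothing measured here explains this flat picture. The compounds shown leave open whether an amine or a carboxylic acid carried on this nitrogen would move the number beyond the scatter.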